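The compounds below may be only part of what the source reports. "The series", "measured", "known", "first", "only" and "open" are said of these compounds alone.

Measured in an ADME assay on LLC-MK2 cells (Macaca mulatta) for cytotoxicity, read by MTT assay, with a stated time of 48 h; on this read-out lower numbers stand for higher toxicity in this test and higher numbers for lower toxicity in this test:
- Compound 1 `COc1ccc(/C=C(\C)C(=O)/C=C/c2ccc([N+](=O)[O-])cc2)cc1`: 20100 nM
- Compound 2 `C/C(=C\c1ccc([N+](=O)[O-])cc1)C(=O)/C=C/c1ccc([N+](=O)[O-])cc1`: 32500 nM
- Compound 3 `COc1ccc(/C=C/C(=O)/C(C)=C/c2ccc(N(C)C)cc2)cc1`: 285000 nM

Compound 3 has the highest number of the three, clearly beyond the scatter from both others. Compound 4 `C/C(=C\c1ccc(N(C)C)cc1)C(=O)/C=C/c1ccc([N+](=O)[O-])cc1` differs from it by one swap: nitro in place of methoxy on an aromatic carbon. The same kind of swap gave a 1.6-fold higher number from compound 1 to compound 2 (0.21 log units; within the scatter), so that step alone predicts no real change. However, compound 1 already carried a nitro group before its swap, and compound 3 carries none. Compound 1 at 20100 nM and compound 2 at 32500 nM both bear nitro and both sit well under compound 3 at 285000 nM. A lower number is therefore expected, though three compounds are a thin basis. The expected change is a 2.6-fold lower number from compound 3 to compound 4 (0.41 log units; beyond the scatter). For compound 4 the estimate is 110000 nM, with an expected range of 30000 nM to 400000 nM.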

Compound 4, half-maximal cytotoxic concentration: 167000 nM
The estimate for compound 4 lay 1.5-fold (0.18 log units) below the measured number, and the stated range covers the measured number.
By their numbers in this assay, from the lowest: compounds 1 and 2 (each within the scatter of the next); then compounds 4 and 3 (each within the scatter of the next).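

In this assay, nitro in place of methoxy on this aromatic carbon gives no real change on this second core, a 1.7-fold lower number from compound 3 to compound 4 (0.23 log units; within the scatter). Even so, the same swap does not behave identically on the two cores: the same change on two cores in this assay, a 1.6-fold higher number (0.21 log units; within the scatter) from compound 1 to compound 2 and a 1.7-fold lower number (0.23 log units; within the scatter) from compound 3 to compound 4, 2.8-fold (0.44 log units) apart, beyond the scatter of two such steps The larger shifts come with dimethylamino, which gives a 5.1-fold higher number from compound 2 to compound 4 (0.71 log units; beyond the scatter) in place of nitro and an 8.3-fold higher number from compound 1 to compound 4 (0.92 log units; beyond the scatter) in place of methoxy. The compounds shown leave open whether these higher numbers belong to dimethylamino alone or would also come with a simple primary amine or a carboxylic acid on that aromatic carbon.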